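The source may hold more compounds than are shown below. What is called first, only, known or untested is meant among the compounds shown, and "the series" means these compounds.

Measured in an ADME assay on CHO-K1 cells (Cricetulus griseus) for cytotoxicity, read by MTT assay, with a stated time of 24 h; on this read-out lower numbers stand for higher toxicity in this test and higher numbers for lower toxicity in this test:
- compound 1 `Oc1ccccc1NC(=S)Nc1ccc2[nH]ccc2c1`: 509000 nM
- compound 2 `COc1ccc(NC(=S)Nc2ccc3[nH]ccc3c2)cc1`: 476000 nM

Only these two values are available so far. Compound 2, at 476000 nM, lies within the scatter of compound 1, at 509000 nM, so the two cannot be told apart on this read-out.

The next compound is compound 3 `CC(=O)Nc1ccc(NC(=S)Nc2ccc3[nH]ccc3c2)cc1`, which carries acetamido in place of methoxy on an aromatic carbon, para to a large group: acetamido in place of methoxy on an aromatic carbon.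

Within the data shown here, no measured pair differs in one place only, so the size of this change in this assay cannot be read from a direct precedent. The expectation rests on just two compounds, and their values say little about this particular replacement. Among the measured compounds shown here, with compound 1 at 509000 nM and compound 2 at 476000 nM, the only guide is a pair of values within the scatter, so no step beyond the scatter is expected, in either direction.

The expected step is a 1.1-fold higher number from compound 2 to compound 3 (0.02 log units; within the scatter). Compound 3 is estimated at 500000 nM, with an expected range of 230000 nM to 1000000 nM.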

Compound 3, concentration lethal to 50% of the cells: 1040000 nM
Compound 3: the middle estimate sits 2.1-fold (0.32 log units) below what was measured; the whole stated range lies below it.
By their numbers in this assay, from the lowest: compounds 2 and 1 (each within the scatter of the next); then compound 3.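

In this assay, this position, para to a large group on the six-membered aromatic ring, proves sensitive to the group it carries: acetamido in place of methoxy gives a 2.2-fold higher number from compound 2 to compound 3 (0.34 log units; beyond the scatter) and thus the first separation beyond the scatter in the series, in the direction of lower toxicity in this test. Among these compounds, the earlier compounds offered no comparison in one place, so this is the only direct reading of a substituent change here, and it involves both a step from 2 to 4 heavy atoms and a step from 0 to 1 hydrogen-bond donor, which this single pair cannot separate. Nothing measured bears on the reason for the higher number.

Open, from the compounds shown here alone, is which part of acetamido carries the step, a question that an amine, a longer chain such as propionamido, or a carboxylic acid at the same place would address. Also open, going by these compounds, is whether the step holds for acetamido elsewhere on the ring, or is specific to this position.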